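Pentyl versus methyl on the chalcogen of two cores

The source may hold more compounds than are shown below. What is called first, only, known or untested is meant among the compounds shown, and "the series" means these compounds.

Compound 1 `CCCCCSc1nc(NCc2ccc([Se]C)cc2)c2ccccc2n1` gives 75200 nM in a functional assay on MCF7 cells (Homo sapiens) for cytotoxicity, read by MTT assay, with a stated time of 72 h; on this read-out lower numbers stand for stronger inhibition of growth and higher numbers for weaker inhibition of growth. Compound 2 `CSc1nc(NCc2ccc([Se]C)cc2)c2ccccc2n1` reaches only a limit of the assay, > 100000 nM in this assay, which is the limit of > 100000 nM in this assay, at which 1 of the 3 values shown sits. The step of an at least 1.3-fold higher number from compound 1 to compound 2 (0.12 log units; that floor lies within the scatter) corresponds to hydrogen in place of butyl on a saturated chain carbon bound to a sulfur. Compound 3 `CCCCC[Se]c1nc(N)c2cccnc2n1` gives 53800 nM in this assay; the difference between the core of compound 3 and the core of compound 1 is not broken down here, as the two differ in more than one place. Compound 4 `C[Se]c1nc(N)c2cccnc2n1` is not yet measured; it differs from compound 3 by hydrogen in place of butyl on a saturated chain carbon bound to a selenium atom. The place is a saturated chain carbon bound to a selenium atom rather than to a sulfur, so this is the same kind of change as from compound 1 to compound 2, not the same one. Resting on the step from compound 1 to compound 2 an at least 1.3-fold higher number from compound 1 to compound 2 (0.12 log units; that floor lies within the scatter) and on the value of compound 3 53800 nM, the expected step is a 1.9-fold higher number from compound 3 to compound 4 (0.27 log units; within the scatter). Compound 4 is estimated at 100000 nM, between 45000 nM and 250000 nM.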

Compound 4, concentration for total growth inhibition: > 100000 nM
Compound 4 ended at the assay's limit; the forecaster's own chance of this, stated with the estimate: 50%; the middle value sits exactly at the limit.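

Compound 4 reaches only a limit of this assay, > 100000 nM, which is not a number. Hydrogen in place of butyl on a saturated chain carbon bound to a selenium atom gives an at least 1.8-fold higher number from compound 3 to compound 4 (0.26 log units; that floor lies within the scatter). The pair is compatible with the change carrying over from one core to the other, but neither step is established beyond the scatter, and no size can be transferred between the cores: the same change on two cores in this assay, an at least 1.3-fold higher number (0.12 log units; that floor lies within the scatter) from compound 1 to compound 2 and an at least 1.8-fold higher number (0.26 log units; that floor lies within the scatter) from compound 3 to compound 4; the limit leaves it open whether they differ

On these data alone, what a chain between methyl and pentyl, such as propyl, or a longer chain such as octyl would give on either core remains open. So does whether an amine at the end of the pentyl chain would bring this assay clear of its limit.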